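The compounds below may be only part of what the source reports. "The series", "measured", "known", "first", "only" and "open" are said of these compounds alone.

In an ADME assay on HepG2 cells (Homo sapiens) for cytotoxicity, in the presence of a further agent that is not named here (on this read-out lower numbers stand for stronger inhibition and higher numbers for weaker inhibition), three amides built on one shared core have been measured. Compound 1 `CN(Cc1ccccc1)C(=O)c1nc(Cc2ccccc2C(F)(F)F)n(C)c(=O)c1O` gives > 100000 nM, which is a limit of the assay and not a number. Compound 2 `Cn1c(Cc2ccccc2C(F)(F)F)nc(C(=O)Nc2ccccc2)c(O)c1=O` gives > 100000 nM, which is also a limit. Compound 3 `Cn1c(Cc2ccccc2C(F)(F)F)nc(C(=O)NCc2ccccc2F)c(O)c1=O` gives > 100000 nM, again a limit. Compound 2 therefore has no exact position on the scale, and the whole set comes down to the limit of > 100000 nM in this assay, at which 3 of the 3 values shown sit.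

Compound 4 `Cn1c(Cc2ccccc2C(F)(F)F)nc(C(=O)NCc2ccccc2)c(O)c1=O` has not yet been measured. Its difference from compound 2 is benzyl in place of phenyl on an amide-type nitrogen. The closest measured change is a step that the two limits leave unreadable from compound 2 to compound 3, which puts 2-fluorobenzyl in place of phenyl at that same nitrogen. The other two changes at this amide are a step that the two limits leave unreadable from compound 1 to compound 2 and a step that the two limits leave unreadable from compound 1 to compound 3. None of these steps has a size that can be read, so they give no direction. All three compounds nevertheless stay at the limit, so no step beyond the usual scatter is expected here, and the estimated step is a number no higher from compound 2 to compound 4 (the limit leaves the size open). The expected value for compound 4 is 100000 nM, with an estimated range from 50000 nM to 200000 nM.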

Compound 4, half-maximal inhibitory concentration: > 100000 nM
Compound 4 gave a limit, no number; the forecaster's own chance of this, stated with the estimate: 85%; the middle value sits exactly at the limit.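

In this assay compound 4 gives > 100000 nM, which is a limit of the assay and not a number. Compound 1, compound 2 and compound 3 also stand at limits, so no step from any of them to compound 4 can be read, and the set remains at one value: the limit of > 100000 nM in this assay, at which 4 of the 4 values shown sit.

The compounds shown leave open whether any change at this amide shifts the read-out at all.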